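An Octyl Chain Replaces the Aryl Ring in Compound 4

The source may report more compounds than this note shows. Statements on the series, on what has been measured and on what is new or still open speak of the compounds shown alone.

Compound 3 `COc1ccc(/C=N/NC(=O)c2cnc3ccc(F)cc3c2N[C@@H](CSc2ccccc2)CC(=O)N(C)C)c(F)c1` has no number in an ADME assay on Vero cells (Chlorocebus sabaeus) for cytotoxicity, read by MTT assay, with a stated time of 72 h; on this read-out lower numbers stand for stronger inhibition and higher numbers for weaker inhibition; its entry reads "not determined" (no result reported). Of the two companions sharing its core, compound 2 `CN(C)C(=O)C[C@H](CSc1ccccc1)Nc1c(C(=O)N/N=C/c2ccc(Br)s2)cnc2ccc(F)cc12` is likewise recorded as "not determined" (no result reported). Compound 1 `CN(C)C(=O)C[C@H](CSc1ccccc1)Nc1c(C(=O)N/N=C/c2ccc(OC(F)(F)F)cc2)cnc2ccc(F)cc12` reaches only a limit of the assay, > 62.5 ug/mL, so that the limit of > 62.5 ug/mL in this assay, at which 1 of the 3 values shown sits, is the sole measured anchor for the series. Compound 4 `CCCCCCCC/C=N/NC(=O)c1cnc2ccc(F)cc2c1N[C@@H](CSc1ccccc1)CC(=O)N(C)C` differs from compound 3 by octyl in place of 2-fluoro-4-methoxyphenyl on a carbon with a double bond to nitrogen. Going by the values given here, with no measured step to guide the direction, the expectation for compound 4 in this assay is a value near the anchor and quite possibly again a limit; the estimate for compound 4 is 55 ug/mL, between 18 ug/mL and 125 ug/mL.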

Compound 4, half-maximal inhibitory concentration: > 62.5 ug/mL
Compound 4: only a limit was reported; the forecaster's own chance of this, stated with the estimate: 50%; middle value at least 1.1-fold (0.05 log units) from the limit.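

Compound 1 and compound 4 both stand at a limit in this assay, not at a number, so no step between them can be read: the limit of > 62.5 ug/mL in this assay, at which 2 of the 4 values shown sit.

The compounds shown leave open whether replacing the aryl ring with octyl shifts cytotoxicity at all.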